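Adding a Third Methoxy Group to a Dimethoxy Chalcone

The source may report more compounds than this note shows. Statements on the series, on what has been measured and on what is new or still open speak of the compounds shown alone.

The study compares aminophenyl chalcones in a functional assay on FM3A cells (Mus musculus) for antiproliferative activity, with a stated time of 48 h; on this read-out higher numbers stand for weaker inhibition and lower numbers for stronger inhibition. Compound 1 `COc1ccccc1/C=C/C(=O)c1ccc(N)cc1` gives 25000 nM in this assay. Compound 2 `COc1cccc(/C=C/C(=O)c2ccc(N)cc2)c1OC` carries one more methoxy group; the difference is methoxy in place of hydrogen on an aromatic carbon and in this assay compound 2 gives 29000 nM. The step of a 1.2-fold higher number from compound 1 to compound 2 (0.06 log units; within the scatter) was small. Compound 3 `COc1cc(/C=C/C(=O)c2ccc(N)cc2)cc(OC)c1` is the most potent of the three measured compounds, giving 12000 nM in this assay; its number stands beyond the scatter from both compound 1 and compound 2. The difference between the core of compound 3 and the core of compound 1 is not broken down here.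

Compound 4 `COc1cc(/C=C/C(=O)c2ccc(N)cc2)cc(OC)c1OC` has not yet been measured. Its change from compound 3 is methoxy in place of hydrogen on an aromatic carbon. Within the data shown here, this is the same kind of change as the one from compound 1 to compound 2, but not the same: in compound 2 the entering methoxy sits ortho to a methoxy group and meta to a large group, whereas in compound 4 it sits ortho to two methoxy groups and para to a large group.

Because the step of a 1.2-fold higher number from compound 1 to compound 2 (0.06 log units; within the scatter) stayed within the scatter, a step of similar size, a 1.2-fold lower number from compound 3 to compound 4 (0.08 log units; within the scatter), is expected in this assay. Compound 4 is therefore estimated to give 10000 nM, with the expected range spanning from 4000 nM to 30000 nM.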

Compound 4, half-maximal inhibitory concentration: 8800 nM
For compound 4 the middle estimate is 1.1-fold (0.06 log units) above the measured one, and the stated range covers the measured number.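

In this assay, methoxy in place of hydrogen on an aromatic carbon gives a 1.4-fold lower number from compound 3 to compound 4 (0.13 log units; within the scatter), and set beside the earlier step, the change shows no readable difference between the two cores: the same change on two cores in this assay, a 1.2-fold higher number (0.06 log units; within the scatter) from compound 1 to compound 2 and a 1.4-fold lower number (0.13 log units; within the scatter) from compound 3 to compound 4, 1.6-fold (0.20 log units) apart, within the scatter of two such steps

On these two cores, then, the change leaves the number within the scatter each time, and the opposite signs of the two steps cannot be read as a real difference in direction. Among these compounds, this does not show that the change is without effect in general or that it would carry to further cores, since only two pairs stand behind it and the entering methoxy does not sit in the same surroundings in both: in compound 4 it is ortho to two methoxy groups and para to a large group, and no pair here tests that place on a second core.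

The compounds shown leave open whether a hydroxyl group, an ethoxy group or a longer chain in that same place would stay as close to the hydrogen compound as methoxy does. They also leave open how the same change would behave with a carboxylic acid in place of the amine.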